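The compounds below may be only part of what the source reports. "The series", "measured", "known", "first", "only" and "open" are said of these compounds alone.

Measured compounds:
- compound 1 `CCOc1cc(-c2ccc3[nH]ccc3c2)cn2c(-c3cc(OC)c(OC)c(OC)c3)nnc12`: 589 nM
- compound 2 `COc1cc(-c2nnc3c(OC4COC4)cc(-c4ccc5[nH]ccc5c4)cn23)cc(OC)c1OC`: 9810 nM
- compound 3 `COc1cc(-c2nnc3c(OC4CC4)cc(-c4ccc5[nH]ccc5c4)cn23)cc(OC)c1OC`: 198 nM

All three share one core and differ only in the group carried on an oxygen on an aromatic ring. In a functional assay on A549 cells (Homo sapiens) for antiproliferative activity, read by MTT assay, with a stated time of 48 h (on this read-out higher numbers stand for weaker inhibition and lower numbers for stronger inhibition), compound 1 stands second highest of the three numbers: compound 3 lies nearer, with a 3.0-fold lower number from compound 1 to compound 3 (0.47 log units; beyond the scatter), while compound 2 lies furthest, with a 17-fold higher number from compound 1 to compound 2 (1.22 log units; beyond the scatter).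

Compound 4 `COc1cc(-c2nnc3c(OC4CN(C(C)(C)C)C4)cc(-c4ccc5[nH]ccc5c4)cn23)cc(OC)c1OC` has not yet been measured. It differs from compound 1 in one place: 1-(tert-butyl)azetidin-3-yl in place of ethyl on an oxygen on an aromatic ring. The entering group brings one four-membered non-aromatic ring with 1 hetero atom and one hydrogen-bond acceptor, where the ethyl of compound 1 had neither.

Going by the values given here, two measured steps bear on this change. Replacing ethyl by cyclopropyl gave a 3.0-fold lower number from compound 1 to compound 3 (0.47 log units; beyond the scatter), a modest gain. Replacing ethyl by oxetan-3-yl gave a 17-fold higher number from compound 1 to compound 2 (1.22 log units; beyond the scatter), a large loss, and the move from compound 2 to compound 3 shows the span between the two: a 50-fold lower number from compound 2 to compound 3 (1.70 log units; beyond the scatter). The group entering compound 4 is, by name, closer in kind to oxetan-3-yl than to cyclopropyl, though it is larger than either and carries a tert-butyl on its nitrogen. The expectation is therefore a higher number than compound 1 in this assay, beyond the scatter, but with wide uncertainty, estimated at a 5.1-fold higher number from compound 1 to compound 4 (0.71 log units; beyond the scatter). Compound 4 is estimated to give 3000 nM, within a range from 600 nM to 15000 nM.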

Compound 4, half-maximal inhibitory concentration: > 10000 nM
Compound 4: only a limit was reported (the forecaster's own chance of this, stated with the estimate: 5%); at least 3.3-fold (0.52 log units) between middle value and limit.
By their numbers in this assay, from the lowest: compound 3; then compound 1; then compound 2. At a limit, above all of these: compound 4.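

In this assay compound 4 is reported only as a limit of the assay, not as a number: the limit of > 10000 nM in this assay, at which 1 of the 4 values shown sits.

Measured against the ethyl group, the 1-(tert-butyl)azetidin-3-yl group gives an at least 16-fold higher number from compound 1 to compound 4 (1.22 log units; beyond the scatter), a large step, and measured against the cyclopropyl group it gives an at least 50-fold higher number from compound 3 to compound 4 (1.70 log units; beyond the scatter), also a large step. This shows that a second group with a four-membered non-aromatic ring containing a hetero atom, here much larger and holding nitrogen rather than oxygen, also sits at the weak end on this oxygen, as oxetan-3-yl does in compound 2. Measured against the oxetan-3-yl group, the 1-(tert-butyl)azetidin-3-yl group gives only an at least 1.0-fold higher number from compound 2 to compound 4 (0.00 log units; that floor lies within the scatter), so these two cannot be put in order.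

The compounds shown leave open whether the loss in compound 4 goes with the ring nitrogen, the tert-butyl on it, or the overall size of the group. A plain azetidin-3-yl carrying a hydrogen on its nitrogen, a cyclobutyl ring and a longer chain such as n-propyl would each help to separate these possibilities.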